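Pentyl in place of hydroxymethyl: compound 4 from compound 3

This account rests on a few compounds, and the source may have more. Where it says the series, first, only, none or still open, it means among the compounds named here.

Three compounds of the shared core have numbers in an ADME assay on SK-OV-3 cells (Homo sapiens) for cytotoxicity, read by sulforhodamine B assay, with a stated time of 48 h, tested at 10 uM; on this read-out lower numbers stand for less inhibition and higher numbers for more inhibition at the one concentration tested (going by the name of the read-out). Compound 1 `COc1nc2ccc(Br)cc2cc1C(c1ccccc1)n1cc(-c2ccccc2F)nn1` gives 7.33%, compound 2 `COc1nc2ccc(Br)cc2cc1C(c1ccccc1)n1cc(-c2ccc(F)cc2)nn1` gives 14.3%, and compound 3 `COc1nc2ccc(Br)cc2cc1C(c1ccccc1)n1cc(CO)nn1` gives 3.23%. Compound 3 stands lowest of the three: its nearest neighbour is compound 1, at a number 4.1 percentage points lower from compound 1 to compound 3 (within the scatter), and its furthest is compound 2, at a number 11.1 percentage points lower from compound 2 to compound 3 (beyond the scatter).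

Compound 4 `CCCCCc1cn(C(c2ccccc2)c2cc3cc(Br)ccc3nc2OC)nn1` has not been measured. Its difference from compound 3 is butyl in place of hydroxy on a saturated chain carbon bound to an aromatic carbon; cut one bond further out, the same difference reads hydroxymethyl to pentyl.

The two measured steps at this position both run toward hydroxymethyl: from a 2-fluorophenyl at a number 4.1 percentage points lower from compound 1 to compound 3 (within the scatter) and from a 4-fluorophenyl at a number 11.1 percentage points lower from compound 2 to compound 3 (beyond the scatter). Within the data shown here, neither step covers a plain chain, so the present change has no direct precedent among the measured compounds. Both steps, however, show the hydroxymethyl compound at the low end, one of them beyond the scatter. Compound 4 is therefore expected to sit slightly above compound 3, with a step of a number 5.8 percentage points higher from compound 3 to compound 4 (within the scatter), which may fall within the scatter. In this assay compound 4 is estimated at 9%, within a range from 0% to 20%.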

Compound 4, a percentage reported as inhibition, at one concentration (the size of the read-out at that concentration, not a potency): 10.5%
Compound 4: middle estimate off by 1.5 percentage points, on the low side; the range from low to high includes it.
By their numbers in this assay, from the lowest: compounds 3, 1, 4 and 2 (each within the scatter of the next, the first and the last beyond it).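

In this assay, the step of a number 7.3 percentage points higher from compound 3 to compound 4 (within the scatter) shows that butyl in place of hydroxy on this saturated chain carbon, which removes the only hydrogen-bond donor of the group, does not separate the pentyl compound from the hydroxymethyl compound. Among these compounds, with a number 3.8 percentage points lower from compound 2 to compound 4 (within the scatter) and a number 3.2 percentage points higher from compound 1 to compound 4 (within the scatter) as well, a plain chain on the triazole cannot be told apart from either fluorophenyl group, so no aromatic ring is needed at this position for a number of this size, and the only pair still separated here is compound 2 and compound 3. No measurement at hand accounts for these numbers.

From the compounds shown here alone, whether an amine, a carboxylic acid or a longer chain such as decyl in this position would give a step beyond the scatter from compound 4 remains open. Going by these compounds, each number in this assay comes from one concentration, so how the four compounds would compare in potency also remains open.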